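The compounds below may be only part of what the source reports. "The series", "measured", "known", "first", "only" and "open" are said of these compounds alone.

Measured so far:
Compound 1 `COc1ccc(-c2nc(C)c(C(=O)CSc3nc(-c4cccc(OC)c4)c(C#N)c(=O)[nH]3)s2)cc1` — 43.2%
Compound 2 `COc1cccc(-c2nc(SCC(=O)c3sc(-c4ccccc4)nc3C)[nH]c(=O)c2C#N)c1` — 80.3%

Compound 2 stands highest of the two numbers in a functional assay on U-87MG ATCC cells for antiproliferative activity against U-87 MG (Homo sapiens), read by MTT assay, with a stated time of 48 h, tested at 50 uM; a lower number here means a stronger effect, a higher number a weaker effect of the compound at the concentration tested; its nearest neighbour is compound 1, which gives 43.2%. Going by the values given here, the one step in hand, a number 37.1 percentage points higher from compound 1 to compound 2 (beyond the scatter), is a hydrogen in place of methoxy on an aromatic carbon and was large.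

Compound 3 `Cc1nc(-c2ccccc2)sc1C(=O)CSc1nc(-c2cccc(Cl)c2)c(C#N)c(=O)[nH]1` differs from compound 2 by chloro in place of methoxy on an aromatic carbon, on an aromatic carbon of a six-membered aromatic ring of carbon only. Among the compounds with values here, no measured step swaps methoxy for chloro, and the one known step concerns a different methoxy on the shared core, so it bears only loosely here. With so thin a basis no step beyond the scatter is firmly expected in this assay, and the direction is open. Compound 3 is therefore estimated near compound 2, at 72% (range 45% to 95%), an expected step of a number 8.3 percentage points lower from compound 2 to compound 3 (within the scatter).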

Compound 3, a percentage reported as activity, at one concentration (the size of the read-out at that concentration, not a potency): 50.6%
Compound 3: middle estimate off by 21.4 percentage points, on the high side, within the range that was stated.
By their numbers in this assay, from the lowest: compounds 1 and 3 (each within the scatter of the next); then compound 2.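

In this assay, the change from 3-methoxyphenyl to 3-chlorophenyl gives a number 29.7 percentage points lower from compound 2 to compound 3 (beyond the scatter), toward the stronger effect at the concentration tested. Going by these compounds alone, the earlier step concerned the methoxy elsewhere on the shared core, so this is the first sign that the read-out also responds to the group at this place, though it rests on one pair. No evidence in hand accounts for the step.

Still open, as far as these compounds go, is how a bare hydrogen, an amine or a carboxylic acid at this place would read, so one swap gives no trend across substituents. Also open, from the compounds shown here alone, is whether 3-chlorophenyl and the methoxy elsewhere on the core would add up when combined, and a single concentration says nothing of potency.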